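The source may report more compounds than this note shows. Statements on the series, on what has been measured and on what is new or still open speak of the compounds shown alone.

Working notes on the series. Compound 2 `CCOCCOn1c(-c2cccc(C#N)c2)nc(C)c1C(=O)OCC` gives 6250 nM in a functional assay on a cell-free system (plasma, Oryctolagus cuniculus) for inhibition, with stated times of 5 min, 1 min and 6 min (a higher number here means a weaker inhibitor, a lower number a stronger inhibitor), the lowest of the two numbers in hand. Compound 1 `CCOC(=O)c1c(C)nc(-c2ccc(OCC(C)C)c(C#N)c2)n1O` gives 16800 nM in this assay. Compound 3 `CCOC(=O)c1c(C)nc(-c2cccc(C#N)c2)n1OCC(N)=O` gives only a limit in this assay, > 30000 nM. Compound 4 `CCOC(=O)c1c(C)nc(-c2cccc(C#N)c2)n1OCc1ccc(F)cc1` is not yet measured; the change from compound 2 is 4-fluorophenyl in place of ethoxymethyl on a saturated chain carbon bound to an oxygen on an aromatic ring. Going by the values given here, the one step at the same place, an at least 4.8-fold higher number from compound 2 to compound 3 (0.68 log units; beyond the scatter), runs to a limit of > 30000 nM in this assay, at which 1 of the 3 values shown sits, and so bounds only what a carbamoyl does there; no measured step covers an aryl group at this position. The expectation for compound 4 is therefore a step of about a 1.6-fold lower number from compound 2 to compound 4 (0.19 log units; within the scatter) in this assay, with no direction firmly supported. Compound 4 is estimated at 4000 nM, within 1000 nM to 15000 nM.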

Compound 4, half-maximal inhibitory concentration: 5880 nM
Beside the measured number, compound 4's estimate is 1.5-fold (0.17 log units) below it; the range from low to high includes it.
By their numbers in this assay, from the lowest: compounds 4 and 2 (each within the scatter of the next); then compound 1. At a limit, above all of these: compound 3.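

In this assay, the change to 4-fluorophenyl on a saturated chain carbon bound to an oxygen on an aromatic ring gives a 1.1-fold lower number from compound 2 to compound 4 (0.03 log units; within the scatter), so an aromatic ring is accommodated here with no reading of a gain or a loss. The carbamoyl group now compares with a second group at this place, giving an at least 5.1-fold lower number from compound 3 to compound 4 (0.70 log units; beyond the scatter), a step that is only a bound. Compound 3 stands at a limit: the limit of > 30000 nM in this assay, at which 1 of the 4 values shown sits.

As far as these compounds go, what a plain phenyl without the fluorine would give here stays open. So does the outcome for an amine, a carboxylic acid or a longer chain at this place.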